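The source may hold more compounds than are shown below. What is called first, only, known or untested is meant among the compounds shown, and "the series" means these compounds.

Working notes on the series. Compound 1 `O=C(COc1cccc2ccccc12)N/N=C/c1ccc(Cl)cc1` and compound 2 `O=C(COc1cccc2ccccc12)N/N=C/c1ccccc1` share one core and differ only on the aromatic ring at the far end. In an ADME assay on HEL cells (Homo sapiens) for cytotoxicity (on this read-out higher numbers stand for lower toxicity in this test and lower numbers for higher toxicity in this test), compound 1 gives 100 ug/mL. In this assay compound 2 gives 100 ug/mL. Within the data shown here, the single measured step, no change at the digits printed from compound 1 to compound 2 (within the scatter), shows that exchanging hydrogen for chloro on that aromatic carbon left the read-out where it was. Among the measured compounds shown here, compound 2 therefore stands level with compound 1 at the digits recorded, with no measured compound departing from it beyond the scatter.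

Compound 3 `COc1ccc(/C=N/NC(=O)COc2cccc3ccccc23)cc1` is the next member to be measured. Relative to compound 2 the change is methoxy in place of hydrogen on an aromatic carbon. For the measured compounds named here, the only step that bears on it is the one from compound 1 to compound 2, a substitution on the same ring, and that step was flat. On that basis the step from compound 2 to compound 3 in this assay is expected to show no change beyond the scatter, no change at the digits printed from compound 2 to compound 3 (within the scatter). Compound 3 is thus estimated at 100 ug/mL, with a range from 50 ug/mL to 200 ug/mL.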

Compound 3, minimum cytotoxic concentration: 20 ug/mL
Beside the measured number, compound 3's estimate is 5.0-fold (0.70 log units) above it, outside the stated range (below it).
By their numbers in this assay, from the lowest: compound 3; then compounds 1 and 2 (each within the scatter of the next).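

In this assay the position para to a large group proves sensitive to what it carries: methoxy in place of hydrogen brings a 5.0-fold lower number from compound 2 to compound 3 (0.70 log units; beyond the scatter) and so reads as higher toxicity in this test, while methoxy in place of chloro brings a 5.0-fold lower number from compound 1 to compound 3 (0.70 log units; beyond the scatter) in the same direction. The flat exchange of chloro and hydrogen therefore does not describe this position in general, since among the three groups shown only methoxy separates from the others, and the two routes to compound 3 agree in size. Nothing available on the series explains this shift in the read-out.

The compounds shown leave open whether the lower number follows from the attached oxygen or from methoxy as a whole, a question that a hydroxyl, an ethoxy or a dimethylamino group at the same place would help to answer. They also leave open whether methoxy elsewhere on this ring, or on a different shared core, would produce a step of similar size.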